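Sulfonamide series: mouse exposure after intraperitoneal dosing

This account rests on a few compounds, and the source may have more. Where it says the series, first, only, none or still open, it means among the compounds named here.

Two compounds have readings in an ADME assay on the whole organism (Mus musculus, strain CD-1) for pharmacokinetics, read by LC-MS, in a xenograft, with a stated time of 24 h, at a dose of 100 mg/kg by the intraperitoneal route; on this read-out lower numbers stand for lower exposure and higher numbers for higher exposure at the dose given. Compound 1 `CC(C)(C)NS(=O)(=O)c1cccc(NC(=O)c2ncc(NS(C)(=O)=O)nc2N2CCC3(CC2)CC3)n1` gives 62400 ng.h/mL. Compound 2 `CC(C)(C)NS(=O)(=O)c1cccc(NC(=O)c2ccc(NS(=O)(=O)C3(C)CC3)cc2N2CCC3(CC2)CC3)c1` gives 155000 ng.h/mL, the higher of the two numbers, and compound 1 sits below it by a gap beyond the usual scatter. The two structures differ in more than one place, so no single change can be tied to that gap.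

Compound 3 `CC(C)(C)NS(=O)(=O)c1cccc(NC(=O)c2ccc(NS(C)(=O)=O)cc2N2CCC3(CC2)CC3)c1` is not yet measured in this assay. It departs from compound 2 in one place: methyl in place of 1-methylcyclopropyl on a sulfonyl sulfur. Among the measured compounds shown here, no measured pair shows this change on its own, so nothing here tells its direction.

With that in mind, the step is expected to be small, most likely a modest drop or none beyond the scatter: a 1.5-fold lower number from compound 2 to compound 3 (0.17 log units; within the scatter). Compound 3 is therefore estimated at 105000 ng.h/mL, within a range from 50000 ng.h/mL to 200000 ng.h/mL.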

Compound 3, area under the concentration-time curve: 78600 ng.h/mL
Compound 3: middle estimate off by 1.3-fold (0.13 log units), on the high side; the measured number falls inside the stated range.
By their numbers in this assay, from the lowest: compounds 1, 3 and 2 (each within the scatter of the next, the first and the last beyond it).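

Methyl in place of 1-methylcyclopropyl on a sulfonyl sulfur gives the only single-place reading at this position so far, and in this assay it amounts to a 2.0-fold lower number from compound 2 to compound 3 (0.29 log units; within the scatter), so the two sulfonyl groups cannot be told apart on this read-out. On this pair, then, the ring and the larger group can leave the sulfonyl sulfur without a step beyond the scatter, although one pair on one core gives no trend for this position. Nothing available bears on what lies behind this step.

Still open, from the compounds shown here alone, is how a longer chain such as n-butyl, an amine or a carboxylic acid on the sulfonyl sulfur would read. Also open, going by these compounds, is whether the same change gives a similar step on the core of compound 1.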